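Cytotoxicity notes on three measured compounds and one pending

The source may hold more compounds than are shown below. What is called first, only, known or untested is meant among the compounds shown, and "the series" means these compounds.

Measured so far:
compound 1 `O=C(Nc1ccccc1)c1c(NC(=O)C(F)(F)F)sc2c1CCCCC2` — > 50000 nM
compound 2 `COC(=O)Nc1sc2c(c1C(=O)Nc1ccc(OC)cc1)CCCCC2` — > 50000 nM
compound 3 `CC(C)(C)OC(=O)c1c(N)sc2c1CCCCC2` — > 50000 nM

In an ADME assay on THP-1 cells (Homo sapiens) for cytotoxicity (on this read-out higher numbers stand for lower toxicity in this test and lower numbers for higher toxicity in this test), compound 1 gives > 50000 nM, which is a limit of the assay and not a number. Compound 2 gives > 50000 nM, likewise a limit. Compound 3 gives > 50000 nM, again a limit. Within the data shown here, every value so far sits at the limit of > 50000 nM in this assay, at which 3 of the 3 values shown sit, so compound 1 stands where the other two stand, and no step between measured compounds can be drawn from these three results; the set gives no direction at all, only the limit itself.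

Compound 4 `CC(C)(C)NC(=O)c1c(NC(=O)C(F)(F)F)sc2c1CCCCC2` is the next compound to go into this assay. It differs from compound 1 by tert-butyl in place of phenyl on an amide-type nitrogen. Among the measured compounds shown here, no measured pair in the set carries a change of this kind, so the size of the step has to be guessed from the standing of compound 1 alone. The expectation is that the step that the limit leaves unreadable from compound 1 to compound 4 will show nothing beyond the usual scatter, with compound 4 most likely reported as a limit as well. Compound 4 is estimated at 60000 nM, in the range 25000 nM to 150000 nM.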

Compound 4, half-maximal cytotoxic concentration: > 50000 nM
Compound 4 was reported as a limit; the forecaster's own chance of this, stated with the estimate: 80%; the middle value does not contradict the limit.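

In this assay compound 4 gives > 50000 nM, a limit of the assay and not a number. Among these compounds, compound 1 also stands at a limit, so no step from compound 1 to compound 4 can be read for tert-butyl in place of phenyl. The compounds shown leave open what real value any of them has and which change, if any, would bring a compound onto a readable value: the limit of > 50000 nM in this assay, at which 4 of the 4 values shown sit.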